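A few compounds are considered here, and "the series" means these few. Any claim that something is new, unique, unknown or untested is made for them only; others in the source may bear on it.

For the measured compounds named here, compound 1 `COc1cc(-c2nnc3n2NC(c2ccco2)C(C(=O)c2ccccc2C)S3)cc(OC)c1OC` is the anchor of this small set: in a functional assay on A549 cells (Homo sapiens) for cytotoxicity, read by MTT assay, with a stated time of 48 h (a higher number here means a weaker inhibitor, a lower number a stronger inhibitor), compound 1 gives 80000 nM, the only number among the three values shown. Compound 2 `COc1ccc(C(=O)C2Sc3nnc(-c4cc(OC)c(OC)c(OC)c4)n3NC2c2ccco2)cc1` is recorded only as a limit of the assay, > 100000 nM. Compound 3 `COc1cc(-c2nnc3n2NC(c2ccco2)C(C(=O)c2ccc([N+](=O)[O-])cc2)S3)cc(OC)c1OC` likewise stands at a limit of the assay, > 100000 nM. The two measured changes on a carbonyl carbon read an at least 1.2-fold higher number from compound 1 to compound 2 (0.09 log units; that floor lies within the scatter) and an at least 1.2-fold higher number from compound 1 to compound 3 (0.09 log units; that floor lies within the scatter); both run into (the limit of > 100000 nM in this assay, at which 2 of the 3 values shown sit). Compound 4 `COc1cc(-c2nnc3n2NC(c2ccco2)C(C(=O)c2cccc(Br)c2)S3)cc(OC)c1OC` carries the change (3-bromophenyl in place of 2-methylphenyl on a carbonyl carbon). Since both measured steps at this position ended at the limit, a higher number in this assay is expected for compound 4, a step of about a 1.3-fold higher number from compound 1 to compound 4 (0.10 log units; within the scatter). Compound 4 is therefore estimated at 100000 nM, within 50000 nM to 200000 nM.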

Compound 4, half-maximal inhibitory concentration: 36900 nM
Compound 4: the middle estimate sits 2.7-fold (0.43 log units) above what was measured; the whole stated range lies above it.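

The carbonyl position does not lead only towards the limit: the 3-bromophenyl group moves the number down, a 2.2-fold lower number from compound 1 to compound 4 (0.34 log units; beyond the scatter). Set against the other two aryl groups, the gap is also beyond the scatter, an at least 2.7-fold lower number from compound 3 to compound 4 (0.43 log units; beyond the scatter) and an at least 2.7-fold lower number from compound 2 to compound 4 (0.43 log units; beyond the scatter). Those two steps are floors, not sizes, as each starts from a limit of the assay: the limit of > 100000 nM in this assay, at which 2 of the 4 values shown sit.

The compounds shown do not separate the bromine from its ring place, as 2-methylphenyl and 3-bromophenyl differ in both. On these data alone, how a 3-methylphenyl or 3-aminophenyl group would read on this carbonyl carbon stays open.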